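Working notes: chain-terminal swap in the benzylamide series

This account rests on a few compounds, and the source may have more. Where it says the series, first, only, none or still open, it means among the compounds named here.

The series shares the benzylamide core. Compound 1 `NCC(N)C(=O)NCc1ccccc1` carries an amino group on the chain; in a functional assay on the whole organism (strain NMRI) with Mus musculus as the target, in the maximal electroshock model, with a stated time of 30 min (on this read-out higher numbers stand for an effect only at larger amounts of compound and lower numbers for an effect already at smaller amounts), compound 1 gives only a limit of the assay, > 68 mg/kg. Compound 3 `C#CCOCC(N)C(=O)NCc1ccccc1` carries a propargyloxy group at that place, and in this assay compound 3 gives 46 mg/kg. Among the measured compounds shown here, the one measured step, an at least 1.4-fold lower number from compound 1 to compound 3 (0.16 log units; that floor lies within the scatter), rests on that limit of > 68 mg/kg in this assay, at which 1 of the 3 values shown sits, and is therefore read loosely. Compound 2 `CCCC[C@@H](N)C(=O)NCc1ccccc1` has a butyl chain, and in this assay compound 2 gives 23 mg/kg, the lowest of the two numbers shown, with compound 3 the nearest and within the scatter of it.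

Compound 4 `CSCC[C@@H](N)C(=O)NCc1ccccc1` differs from compound 2 by methylsulfanyl in place of ethyl on a saturated chain carbon, three bonds along the chain from an amine nitrogen and a carbonyl carbon. For the measured compounds named here, no measured step touches this position or this kind of exchange; the step from compound 1 to compound 3 concerns a different chain carbon and a different pair of groups, so it only shows that a swap on the chain can move the number modestly. The change from ethyl to methylsulfanyl keeps the heavy-atom count, so no step beyond the scatter is expected, with a slight lean toward a higher number, expressed as a 1.4-fold higher number from compound 2 to compound 4 (0.14 log units; within the scatter). The estimate for compound 4 in this assay is 32 mg/kg, between 14 mg/kg and 75 mg/kg.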

Compound 4, dose for half-maximal effect: 75 mg/kg
Beside the measured number, compound 4's estimate is 2.3-fold (0.37 log units) below it; the range from low to high includes it.
By their numbers in this assay, from the lowest: compounds 2, 3 and 4 (each within the scatter of the next, the first and the last beyond it).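

In this assay, methylsulfanyl in place of ethyl on a saturated chain carbon, three bonds along the chain from an amine nitrogen and a carbonyl carbon, gives a 3.3-fold higher number from compound 2 to compound 4 (0.51 log units; beyond the scatter), so this position does respond to the exchange, modestly but beyond the scatter, even though the heavy-atom count of the group stays the same. Of the steps shown, this is the only one with a measured number at both ends, and it therefore gives the series its first firm reading of a chain swap, at a different chain carbon and with a different pair of groups from the earlier step. Nothing in the data shown accounts for the size or direction of this step.

The compounds shown leave open whether methoxy or hydroxyl at this place would track methylsulfanyl or stay with ethyl, and so whether the sulfur atom or the group as a whole goes with the higher number. Also open, on these data alone, is whether the same exchange gives a similar step further out on a longer chain, such as pentyl changing to a 3-(methylsulfanyl)propyl group.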